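Ketal oxygen of compound 1: from hydrogen to a diol-bearing chain

The source may hold more compounds than are shown below. What is called first, only, known or untested is meant among the compounds shown, and "the series" means these compounds.

Among the measured compounds shown here, compound 1 `CC(=O)O[C@@H]1[C@H](OC/C2=C/[C@@H]3[C@@H](C(C)C)CC=C(C)[C@@H]3C[C@H](OC(=O)/C=C/c3cn(C)cn3)[C@]3(C)C=C[C@@]2(O)O3)OC[C@@H](O)[C@H]1O` holds the lowest number of the three measured members in a functional assay on MCF7 cells (Homo sapiens), read by ELISA, with a stated time of 20 h (a higher number here means a weaker inhibitor, a lower number a stronger inhibitor), giving 20 nM. Compound 2 `CO[C@]12C=C[C@](C)(O1)[C@@H](OC(=O)/C=C/c1cn(C)cn1)C[C@H]1C(C)=CC[C@H](C(C)C)[C@H]1/C=C\2CO[C@@H]1OC[C@@H](O)[C@@H](OC(C)=O)[C@@H]1O` in this assay gives 50 nM, a gap from compound 1 that lies beyond the scatter. For the measured compounds named here, compound 3 `CO[C@]12C=C[C@](C)(O1)[C@@H](OC(=O)/C=C/c1cn(C)cn1)C[C@@H]1[C@H](/C=C\2CO[C@@H]2OC[C@@H](O)[C@@H](O)[C@@H]2OC(C)=O)[C@@H](C(C)C)C=C[C@@]1(C)O` in this assay gives 20000 nM, far beyond the scatter from compound 1; no single-point step between any pair of these measured compounds is defined, so the values are read as they stand.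

Compound 4 `CC(=O)O[C@@H]1[C@H](OC/C2=C/[C@@H]3[C@@H](C(C)C)CC=C(C)[C@@H]3C[C@H](OC(=O)/C=C/c3cn(C)cn3)[C@]3(C)C=C[C@@]2(OCC(C)(C)CO)O3)OC[C@@H](O)[C@H]1O` has not been measured in this assay. Relative to compound 1 it carries the change (2-(hydroxymethyl)-2-methylpropyl in place of hydrogen on an oxygen on a saturated carbon). This oxygen on a saturated carbon is the only site altered, and the entering chain brings one hydrogen-bond donor and one hydrogen-bond acceptor.

Going by the values given here, no measured step addresses substitution at this oxygen directly. The values of compound 1 and compound 2 show that a close relative with a different grouping on the same kind of site still sits near the low end of the range, while compound 3 shows that a larger rearrangement of the core is what produces the large loss. A small step toward a higher number is therefore expected, a 3.0-fold higher number from compound 1 to compound 4 (0.48 log units; beyond the scatter). Compound 4 is estimated to give 60 nM in this assay, with a range of 20 nM to 250 nM.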

Compound 4, half-maximal inhibitory concentration: 80 nM
Beside the measured number, compound 4's estimate is 1.3-fold (0.12 log units) below it; the measured number falls inside the stated range.
By their numbers in this assay, from the lowest: compound 1; then compounds 2 and 4 (each within the scatter of the next); then compound 3.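

In this assay, among the compounds shown here, 2-(hydroxymethyl)-2-methylpropyl in place of hydrogen on this oxygen on a saturated carbon gives a 4.0-fold higher number from compound 1 to compound 4 (0.60 log units; beyond the scatter), the first direct reading of a change at this position. The step is modest but beyond the scatter, so the change has a real cost, yet the free hydroxy is not essential: with the hydroxy turned into 2-(hydroxymethyl)-2-methylpropoxy, compound 4 still gives 80 nM in this assay, far from the high end of the series. The step shows only the size of the change and not its origin, and nothing available here accounts for it.

Still open, as far as these compounds go, is whether the hydroxy at the end of the entering chain contributes at all, a question that a plain 2,2-dimethylpropyl chain would address directly, while a longer chain, or an amine or a carboxylic acid at the chain end, would show how much variety this oxygen accepts. Also open, from the compounds shown here alone, is whether the same substitution costs a similar amount on a compound with the acetyl group placed as in compound 2, whose sugar differs from that of compound 1.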